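The compounds below may be only part of what the source reports. "The series", "measured", "known", "first", "only" and "open" are said of these compounds alone.

In a functional assay on Huh-7 cells (Homo sapiens) for inhibition, read by sulforhodamine B assay, with a stated time of 72 h (a higher number here means a weaker inhibitor, a lower number a stronger inhibitor), the measured set reads: compound 1 `CC(c1ccc(-c2ccccc2)c(F)c1)c1nnc2n1N=C(c1ccc(OC(F)(F)F)cc1)CS2` at 8400 nM; compound 2 `CC(C)Cc1ccc(C(C)c2nnc3n2N=C(c2ccc(Cl)cc2Cl)CS3)cc1` at 7500 nM; compound 3 `CC(C)Cc1ccc(C(C)c2nnc3n2N=C(c2ccc(Br)cc2)CS3)cc1` at 4900 nM.

Among these three numbers compound 1 has the highest, yet compound 2 and compound 3 both lie within the scatter of it, so no order among them can be drawn. Compound 4 `CC(c1ccc(-c2ccccc2)c(F)c1)c1nnc2n1N=C(c1ccc([N+](=O)[O-])cc1)CS2` differs from compound 1 by nitro in place of trifluoromethoxy on an aromatic carbon. Going by the values given here, the one measured step that alters the aryl group on the carbon with a double bond to nitrogen is a 1.5-fold lower number from compound 2 to compound 3 (0.18 log units; within the scatter), and it stayed within the scatter. Among the compounds with values here, no measured pair swaps trifluoromethoxy for nitro. Compound 4 is thus expected to give a 1.1-fold lower number from compound 1 to compound 4 (0.02 log units; within the scatter), a step not beyond the scatter. The estimate for compound 4 is 8000 nM, expected to lie between 3500 nM and 18000 nM.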

Compound 4, half-maximal inhibitory concentration: 4300 nM
For compound 4 the middle estimate is 1.9-fold (0.27 log units) above the measured one; the measured number falls inside the stated range.
By their numbers in this assay, from the lowest: compounds 4, 3, 2 and 1 (each within the scatter of the next).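

In this assay, going from 4-(trifluoromethoxy)phenyl to 4-nitrophenyl gives a 2.0-fold lower number from compound 1 to compound 4 (0.29 log units; within the scatter). This is the only step shown at this aromatic carbon on the core of compound 1, and it shows that nitro, with fewer heavy atoms and one more hydrogen-bond acceptor, cannot be told apart from trifluoromethoxy here. Nothing available accounts for this result. On these data alone, whether an amine or a carboxylic acid on this carbon would give a step beyond the scatter remains open. So does how nitro would read in place of the bromine of compound 3.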